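Methoxy in Place of Fluoro on the Benzyl Arm

The source may report more compounds than this note shows. Statements on the series, on what has been measured and on what is new or still open speak of the compounds shown alone.

compound 1 `Nc1cc(N)c2nc(-c3ccccc3)c(NCc3ccc(Cl)c(Cl)c3)nc2c1`: 1950 nM
compound 2 `COc1ccc(CNc2nc3cc(N)cc(N)c3nc2-c2ccccc2)cc1OC`: 11500 nM
compound 3 `Nc1cc(N)c2nc(-c3ccccc3)c(NCc3ccc(F)cc3)nc2c1`: 3090 nM

These numbers come from a functional assay on IGROV-1 cells (Homo sapiens) for inhibition, read by sulforhodamine B assay, with a stated time of 48 h; a higher number here means a weaker inhibitor of growth, a lower number a stronger inhibitor of growth. Compound 3 has the second highest of the three; compound 1 is nearest, within the scatter, and compound 2 furthest, beyond it. Compound 4 `COc1ccc(CNc2nc3cc(N)cc(N)c3nc2-c2ccccc2)cc1` differs from compound 3 by methoxy in place of fluoro on an aromatic carbon. Within the data shown here, two measured steps bear on this change: a 3.7-fold lower number from compound 2 to compound 3 (0.57 log units; beyond the scatter) and a 5.9-fold higher number from compound 1 to compound 2 (0.77 log units; beyond the scatter). Both place the methoxy-bearing ring at higher numbers than the halogen-bearing rings, though the measured ring carries two methoxy groups while compound 4 carries one. The number for compound 4 is therefore expected to rise modestly, a 1.9-fold higher number from compound 3 to compound 4 (0.29 log units; within the scatter). Compound 4 is expected to give 6000 nM, within a range from 2500 nM to 15000 nM.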

Compound 4, concentration for 50% growth inhibition: 12900 nM
For compound 4 the middle estimate is 2.2-fold (0.33 log units) below the measured one; measured number inside the range.
By their numbers in this assay, from the lowest: compounds 1 and 3 (each within the scatter of the next); then compounds 2 and 4 (each within the scatter of the next).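

In this assay, replacing fluoro with a single methoxy on this aromatic carbon already gives a 4.2-fold higher number from compound 3 to compound 4 (0.62 log units; beyond the scatter), so the rise does not need the second methoxy carried by compound 2. Removing that second methoxy gives a 1.1-fold higher number from compound 2 to compound 4 (0.05 log units; within the scatter), and the 4-methoxyphenyl arm also stands well apart from the 3,4-dichlorophenyl arm, with a 6.6-fold higher number from compound 1 to compound 4 (0.82 log units; beyond the scatter). Nothing available here explains why methoxy raises the number. Still open, from the compounds shown here alone, is how an amine or a hydroxy group on this carbon would compare with fluoro and methoxy. Also open, going by these compounds, is whether an ethoxy group would raise the number further.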